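Acetylation of a Labdane Diterpenoid Acid

The source may report more compounds than this note shows. Statements on the series, on what has been measured and on what is new or still open speak of the compounds shown alone.

The series rests on a shared diterpenoid core carrying a carboxylic acid and an allylic alcohol on its side chain. Compound 1 `C=C(CC[C@H]1C(=C)CC[C@H]2[C@@](C)(CO)CCC[C@]12C)C(=O)CO` was tested in a functional assay on A549 cells (Homo sapiens) for inhibition, read by MTT assay (on this read-out lower numbers stand for stronger inhibition and higher numbers for weaker inhibition), where compound 1 gives 19.8 ug/mL. Compound 2 `C=C1CC[C@@H]2[C@](C)(CCC[C@]2(C)C(=O)O)[C@H]1CC/C(C)=C/CO`, which keeps the carboxylic acid and the unsaturated hydroxymethyl side chain, was reported in this assay as "not active" (no number reported), so no single number places compound 2 against compound 1; what the two records show is that compound 1 returned a measurable value while compound 2 did not.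

Compound 3 `C=C1CC[C@@H]2[C@](C)(CCC[C@]2(C)C(=O)O)[C@H]1CC/C(C)=C/COC(C)=O` is the next step from compound 2. The change is acetyl in place of hydrogen on an oxygen on a saturated carbon, hydroxy becoming acetoxy on the side chain. Among the measured compounds shown here, no step between measured compounds exists to size this change, and the account of compound 2 gives no number to move from. The expectation for this assay is therefore a weak reading, with a fair chance that the assay again reports only a limit. Compound 3 is estimated at 60 ug/mL, within a range of 20 ug/mL to 200 ug/mL.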

Compound 3, half-maximal inhibitory concentration: 8.9 ug/mL
The estimate for compound 3 lay 6.7-fold (0.83 log units) above the measured number; the measured number lies below the stated range.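

In this assay, among the compounds shown here, compound 3 gives 8.9 ug/mL while compound 2 carries only the report "not active"; no step from compound 2 to compound 3 can be read. The compounds shown leave open how large a change acetoxy in place of hydroxy brings. No evidence on the result is at hand.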